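The source may report more compounds than this note shows. Statements on the series, on what has been measured and on what is new or still open speak of the compounds shown alone.

Measured compounds so far:
- compound 1, `CC[C@H]1OC(=O)[C@H](C)[C@@H](O[C@H]2C[C@@](C)(OC)[C@@H](O)[C@H](C)O2)[C@H](C)[C@@H](O[C@@H]2O[C@H](C)C[C@H](N(C)C)[C@H]2OCCCNCc2cnc3ccccc3c2)[C@](C)(O)C[C@@H](C)CN(C)[C@H](C)[C@@H](O)[C@]1(C)O`; in a physicochemical assay for solubility, at pH 4 (a lower number here means a less soluble compound, a higher number a more soluble compound), compound 1 gives > 10000 ug/mL
- compound 2, `CC[C@H]1OC(=O)[C@H](C)[C@@H](O[C@H]2C[C@@](C)(OC)[C@@H](O)[C@H](C)O2)[C@H](C)[C@@H](O[C@@H]2O[C@H](C)C[C@H](N(C)C)[C@H]2OCCCN(C)Cc2cnc3ccccc3c2)[C@](C)(O)C[C@@H](C)CN(C)[C@H](C)[C@@H](O)[C@]1(C)O`; in this assay compound 2 gives > 10000 ug/mL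

The value of compound 1 in this assay is a limit of the assay, not a number. The value of compound 2 in this assay is likewise a limit, not a number. Among the measured compounds shown here, the only measured step, a step that the two limits leave unreadable from compound 1 to compound 2, is therefore unreadable (the limit of > 10000 ug/mL in this assay, at which 2 of the 2 values shown sit). Compound 2 thus stands at the upper limit of this assay, with no number behind it.

Compound 3, `CC[C@H]1OC(=O)[C@H](C)[C@@H](O)[C@H](C)[C@@H](O[C@@H]2O[C@H](C)C[C@H](N(C)C)[C@H]2OCCCN(C)Cc2cnc3ccccc3c2)[C@](C)(O)C[C@@H](C)CN(C)[C@H](C)[C@@H](O)[C@]1(C)O`, differs from compound 2 by hydrogen in place of 5-hydroxy-4-methoxy-4,6-dimethyloxan-2-yl on an oxygen on a saturated carbon. For the measured compounds named here, no measured step touches this position; the step from compound 1 to compound 2 sits on the amine nitrogen and gives no size at all. Going by the values given here, what is known is only that compound 2 sits at > 10000 ug/mL in this assay, a limit.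

With nothing readable against it, compound 3 is expected to remain at or near that limit in this assay, an estimated step of a number no higher from compound 2 to compound 3 (the limit leaves the size open). The estimate for compound 3 is 10000 ug/mL, expected within 5000 ug/mL to 20000 ug/mL, most likely reported again as a limit.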

Compound 3, solubility: > 10000 ug/mL
Compound 3: no number, only a limit (the forecaster's own chance of this, stated with the estimate: 85%); the middle value sits exactly at the limit.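

Compound 3, like compound 2, gives only a limit in this assay, so no new step can be read between these two compounds: the limit of > 10000 ug/mL in this assay, at which 3 of the 3 values shown sit.

The compounds shown leave open where the true values of compound 1, compound 2 and compound 3 lie, and so what size either change of structure has in this assay.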